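The source may hold more compounds than are shown below. What is called first, only, known or untested is meant among the compounds shown, and "the series" means these compounds.

Three compounds measured in a functional assay on Jurkat cells (Homo sapiens) for activation, with a stated time of 24 h (on this read-out higher numbers stand for an effect only at larger amounts of compound and lower numbers for an effect already at smaller amounts), set the scene. Compound 1 `Oc1ccccc1CNc1ccccc1` is reported as "not active" (no number reported). Compound 2 `Cc1ccc(-c2ccc(NCc3ccccc3O)cc2)cc1` gives 3790 nM. Compound 3 `Oc1ccccc1CNc1ccc(-c2ccccc2Cl)cc1` is reported as "not active" (no number reported), so compound 3 stands without a single number, and one further entry, compound 1, shares that standing; only compound 2 carries a number at all.

Compound 4 `Cc1ccccc1-c1ccc(NCc2ccccc2O)cc1` is the next step: methyl in place of chloro on an aromatic carbon, in words, methyl in place of chloro on an aromatic carbon, ortho to a large group. Among the compounds with values here, no measured pair with a single number shows what such a swap does, so the expectation rests on compound 2 alone. In this assay compound 4 is estimated at 6000 nM, within a range from 2000 nM to 20000 nM.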

Compound 4, half-maximal effective concentration: 5220 nM
For compound 4 the middle estimate is 1.1-fold (0.06 log units) above the measured one, and the stated range covers the measured number.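

Moving the methyl from 4-methylphenyl to 2-methylphenyl gives a 1.4-fold higher number from compound 2 to compound 4 (0.14 log units; within the scatter) in this assay so the two placements cannot be told apart on this read-out. Compound 3, with 2-chlorophenyl, is reported as "not active" (no number reported) while compound 4, with 2-methylphenyl, gives 5220 nM at the same place, so swapping chloro for methyl here separates an entry without a number from one with a number. Nothing available explains that difference. As far as these compounds go, whether an ethyl, a methoxy or an amine at this place would also give a number stays open.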